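The source may hold more compounds than are shown below. What is called first, only, known or untested is meant among the compounds shown, and "the series" means these compounds.

Of the compounds shown here, three of one shared core have been measured in a functional assay on UACC-62 cells (Homo sapiens) for inhibition; a higher number here means a weaker inhibitor of growth, a lower number a stronger inhibitor of growth. Compound 1 `COc1cc(/C=C/C(=O)c2cccc(-n3cc(-c4ccccc4)[nH]c3=O)c2)ccc1O` gives 2010 nM in this assay. Compound 2 `O=C(/C=C/c1cccc(O)c1)c1cccc(-n2cc(-c3ccc(Cl)cc3)[nH]c2=O)c1` gives 1850 nM in this assay. Compound 3 `COc1cc(/C=C/C(=O)c2cccc(-n3cc(-c4ccccc4)[nH]c3=O)c2)cc(OC)c1OC` gives 1520 nM in this assay. The three numbers lie within the usual scatter of one another, so compound 3 is not set apart from compound 1 or from compound 2 by these figures.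

Compound 4 `COc1cc(/C=C/C(=O)c2cccc(-n3cc(-c4cc(OC)c(OC)c(OC)c4)[nH]c3=O)c2)cc(OC)c1OC` has not yet been measured in this assay. It differs from compound 3 in one place: 3,4,5-trimethoxyphenyl in place of phenyl on an aromatic carbon. Among the compounds with values here, no pair of measured compounds shows what a change of this kind does on this core, and the values of compound 1, compound 2 and compound 3 give no hint of a large swing among the variations so far tried. The step from compound 3 to compound 4 is therefore expected to be small, most likely within the scatter, with a slight lean toward a lower number, as a 1.3-fold lower number from compound 3 to compound 4 (0.10 log units; within the scatter). Compound 4 is estimated at 1200 nM in this assay, with a range from 400 nM to 3600 nM.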

Compound 4, concentration for 50% growth inhibition: 1870 nM
The estimate for compound 4 lay 1.6-fold (0.19 log units) below the measured number, within the range that was stated.
By their numbers in this assay, from the lowest: compounds 3, 2, 4 and 1 (each within the scatter of the next).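

In this assay, within the data shown here, the change to 3,4,5-trimethoxyphenyl in place of phenyl on an aromatic carbon of the five-membered ring gives a 1.2-fold higher number from compound 3 to compound 4 (0.09 log units; within the scatter), the first step on the shared core that differs in one place only. At this position, a group of 12 heavy atoms with 3 hydrogen-bond acceptors thus takes the place of one of 6 heavy atoms with none, and the number stays within the scatter. The data offered here contain nothing that would explain this result.

From the compounds shown here alone, whether any group at this position can move the number beyond the scatter remains open, for instance an amine, a carboxylic acid or a longer chain in place of the phenyl. The compounds shown also leave open what a single methoxy group on that phenyl would do, apart from all three together.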